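The source may report more compounds than this note shows. Statements on the series, on what has been measured and on what is new or still open speak of the compounds shown alone.

Measured so far:
compound 1 `Cc1cc(C)c2c(O)cc(-c3cccc(F)c3)nc2n1`: 35.5 nM
compound 2 `Cc1cc(C)c2c(O)cc(-c3cccc(Cl)c3)nc2n1`: 204 nM
compound 3 `Cc1cnc2[nH]c(-c3cccc(Cl)c3)cc(=O)c2c1`: 42.7 nM

All three were tested in a functional assay on CAKI-1 cells (Homo sapiens) for antiproliferative activity; on this read-out higher numbers stand for weaker inhibition of growth and lower numbers for stronger inhibition of growth. Compound 1 and compound 2 share one core and differ only by fluoro in place of chloro on an aromatic carbon, a change that gave a 5.7-fold lower number from compound 2 to compound 1 (0.76 log units; beyond the scatter). Compound 3 carries a different core; how its core differs from that of compound 2 is not broken down here. Compound 3 and compound 1 lie within the scatter of each other, while compound 3 and compound 2 are separated by more than the scatter.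

Compound 4 `Cc1cnc2[nH]c(-c3cccc(F)c3)cc(=O)c2c1` has not yet been measured in this assay. It differs from compound 3 by fluoro in place of chloro on an aromatic carbon, the same change that separates compound 2 from compound 1, at a place described in the same words. Whether that step carries over to the other core is not known from these data, so only part of it is expected to repeat. For compound 4 the step is expected to be a 2.8-fold lower number from compound 3 to compound 4 (0.45 log units; beyond the scatter), resting on a 5.7-fold lower number from compound 2 to compound 1 (0.76 log units; beyond the scatter) and on the value of compound 3, 42.7 nM. Compound 4 is therefore estimated at 15 nM, likely between 6 nM and 40 nM.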

Compound 4, concentration for 50% growth inhibition: 28.2 nM
For compound 4 the middle estimate is 1.9-fold (0.27 log units) below the measured one; measured number inside the range.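

In this assay, fluoro in place of chloro on the core of compound 3 gives a 1.5-fold lower number from compound 3 to compound 4 (0.18 log units; within the scatter), so on this core the effect of the change cannot be told apart from the scatter. Set beside the earlier step, the change does not carry over at its full size from one core to the other: the same change on two cores in this assay, a 5.7-fold lower number (0.76 log units; beyond the scatter) from compound 2 to compound 1 and a 1.5-fold lower number (0.18 log units; within the scatter) from compound 3 to compound 4, 3.8-fold (0.58 log units) apart, beyond the scatter of two such steps. This shows that, for these two cores, the size of the step is not the same, but a single pair on each core cannot show why, nor how the change would behave on any further core.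

The compounds shown carry only fluoro or chloro at this place on the aromatic carbon, so it stays open whether a methoxy group or an amine there would give steps that differ between the two cores in the same way. Which of the differences between the two cores goes with the gap also stays open, as no compound shown changes them one at a time.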